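The compounds below may be only part of what the source reports. "The series", "measured", "known", "first", "only" and "open" are said of these compounds alone.

In a functional assay on HL-60 cells (Homo sapiens) for cytotoxicity, read by MTT assay, with a stated time of 3 days (on this read-out lower numbers stand for stronger inhibition and higher numbers for weaker inhibition), compound 1 `N#Cc1c(O)nc(SCc2nc3ccccc3[nH]2)nc1-c1ccccc1` gives 2.55 nM and compound 2 `N#Cc1c(NC(N)=O)nc(SCc2nc3ccccc3[nH]2)nc1-c1ccccc1` gives 2.9 nM. Among the compounds with values here, these two values lie within the usual scatter of each other, so compound 2 stands level with the only other measured compound. Compound 3 `CN1CCN(c2nc(SCc3nc4ccccc4[nH]3)nc(-c3ccccc3)c2C#N)CC1` keeps the shared core and changes one group, with 4-methylpiperazin-1-yl in place of ureido on an aromatic carbon. Within the data shown here, only one measured step bears on this carbon, ureido in place of hydroxy, which gave a 1.1-fold higher number from compound 1 to compound 2 (0.06 log units; within the scatter). That step is small, but it is a single step, and neither group in it brings a ring as the 4-methylpiperazin-1-yl group does. The expectation is therefore a small shift at most, leaning towards weaker inhibition and probably not beyond the scatter. The estimate amounts to a 1.4-fold higher number from compound 2 to compound 3 (0.14 log units; within the scatter). The expected value for compound 3 is 4 nM, with an estimated range of 1.2 nM to 15 nM.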

Compound 3, half-maximal inhibitory concentration: 2.8 nM
Beside the measured number, compound 3's estimate is 1.4-fold (0.15 log units) above it, and the stated range covers the measured number.
By their numbers in this assay, from the lowest: compounds 1, 3 and 2 (each within the scatter of the next).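

Putting 4-methylpiperazin-1-yl in place of ureido on this aromatic carbon, ortho to a cyano group, leaves the number in this assay within the scatter (a 1.0-fold lower number from compound 2 to compound 3 (0.02 log units; within the scatter)), and the same holds for the change from hydroxy (a 1.1-fold higher number from compound 1 to compound 3 (0.04 log units; within the scatter)). The earlier pair showed only groups without a ring at this carbon, whereas here a group with a six-membered non-aromatic ring and 0 hydrogen-bond donors gives a level result. Nothing available explains why these three different groups read alike.

From the compounds shown here alone, whether a carboxylic acid or a longer alkyl chain on this carbon would also stay level remains open. Going by these compounds, all three compounds also keep the same phenyl group and the same shared core, so it is unknown how much those parts contribute to the read-out.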